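Moving the methyl around the amide-bound phenyl ring

The compounds below may be only part of what the source reports. "The series", "measured", "known", "first", "only" and "open" are said of these compounds alone.

Compound 3 `CC(=O)Oc1ccc(-c2ccc(F)cc2F)cc1C(=O)Nc1cccc(C)c1` shows the highest of the three numbers in a functional assay on the whole organism (strain Kunming) for inhibition, with Mus musculus as the target, in the writhing test, at a dose of 40 mg/kg by the oral route (a lower number here means less inhibition, a higher number more inhibition at the dose given (going by the name of the read-out)), at 19%. Against compound 1 `CC(=O)Oc1ccc(-c2ccc(F)cc2F)cc1C(=O)Nc1ccccc1`, which gives 8.9%, the step of a number 10.1 percentage points higher from compound 1 to compound 3 (beyond the scatter) lies beyond the scatter, while compound 2 `CC(=O)Oc1ccc(-c2ccc(F)cc2F)cc1C(=O)Nc1ccccc1C` gives 12.3% and the step of a number 6.7 percentage points higher from compound 2 to compound 3 (within the scatter) stays within it. Compound 4 `CC(=O)Oc1ccc(-c2ccc(F)cc2F)cc1C(=O)Nc1ccc(C)cc1` differs from compound 3 by 4-methylphenyl in place of 3-methylphenyl on an amide-type nitrogen. Within the data shown here, the only measured step of the same kind is a number 6.7 percentage points higher from compound 2 to compound 3 (within the scatter), within the scatter, and the steps of a number 3.4 percentage points higher from compound 1 to compound 2 (within the scatter) and a number 10.1 percentage points higher from compound 1 to compound 3 (beyond the scatter) show that a methyl on this ring brings at most a modest rise. For compound 4 no step beyond the scatter is expected, a number 4 percentage points lower from compound 3 to compound 4 (within the scatter). Compound 4 is therefore estimated at 15%, with a range from 5% to 26%.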

Compound 4, a percentage reported as inhibition, in the whole organism at one dose (the size of the read-out at that dose, not a potency): 31%
Compound 4: middle estimate off by 16 percentage points, on the low side; measured number above the stated range.
By their numbers in this assay, from the lowest: compounds 1, 2 and 3 (each within the scatter of the next, the first and the last beyond it); then compound 4.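

In this assay the place of the methyl on this ring now makes a clear difference: 4-methylphenyl in place of 3-methylphenyl gives a step (a number 12 percentage points higher from compound 3 to compound 4 (beyond the scatter)), and in place of 2-methylphenyl it gives another (a number 18.7 percentage points higher from compound 2 to compound 4 (beyond the scatter)), whereas the earlier move of the methyl stayed within the scatter. Set against the bare phenyl ring, this methyl also gives more than a slight change (a number 22.1 percentage points higher from compound 1 to compound 4 (beyond the scatter)). Nothing measured here explains why this placement stands apart. From the compounds shown here alone, whether a chlorine, a methoxy group or an ethyl group in this same place would match or pass the methyl remains open.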